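Methoxy in Place of Hydrogen on a Shared Core

The source may hold more compounds than are shown below. What is called first, only, known or untested is meant among the compounds shown, and "the series" means these compounds.

Measured so far:
compound 1 `Cc1cc(C)cc(NC(=O)Cn2ccc(=O)c3ccccc32)c1` — 34000 nM
compound 2 `Cc1cc(C)cc(NC(=O)Cn2ccc(=O)c3ccc(Cl)cc32)c1` — 86000 nM

Of the two measured compounds in a physicochemical assay for solubility, read by chemiluminescence, measured as kinetic solubility (on this read-out higher numbers stand for higher solubility and lower numbers for lower solubility), compound 1 stands lowest, with its nearest neighbour a step away of a 2.5-fold higher number from compound 1 to compound 2 (0.40 log units; beyond the scatter). Compound 3 `COc1ccc2c(c1)c(=O)ccn2CC(=O)Nc1cc(C)cc(C)c1` differs from compound 1 by methoxy in place of hydrogen on an aromatic carbon. Going by the values given here, the only measured step at a comparable position is the one from compound 1 to compound 2, with a chloro rather than a methoxy group entering, so it bears on compound 3 only loosely. A small rise or no change beyond the scatter is expected, and the step from compound 1 to compound 3 is estimated at a 1.2-fold higher number from compound 1 to compound 3 (0.07 log units; within the scatter). Compound 3 is expected to give 40000 nM, within 15000 nM to 100000 nM.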

Compound 3, solubility: 30000 nM
The estimate for compound 3 lay 1.3-fold (0.12 log units) above the measured number; measured number inside the range.
By their numbers in this assay, from the lowest: compounds 3 and 1 (each within the scatter of the next); then compound 2.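

In this assay, methoxy in place of hydrogen on an aromatic carbon of the shared core gives a 1.1-fold lower number from compound 1 to compound 3 (0.05 log units; within the scatter) and so cannot be told from the scatter. The earlier compounds shown here showed only chloro entering, with a 2.5-fold higher number from compound 1 to compound 2 (0.40 log units; beyond the scatter) beyond the scatter, so a new group on this ring need not move the number. No measurement here accounts for this result. On these data alone, whether an amine or a carboxylic acid on this same carbon would give a step beyond the scatter stays open, as does the effect of a longer chain in place of methoxy.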